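Aldehyde to Alcohol on the Triazole Side Chain

The source may hold more compounds than are shown below. What is called first, only, known or untested is meant among the compounds shown, and "the series" means these compounds.

Measured compounds:
- compound 1, `Cn1c(Cc2nn(C)c(=O)c3ccccc23)nnc1SCC(=O)Nc1ccc(Cl)cc1Cl`: 4500 nM
- compound 2, `CCOC(CCn1c(Cc2nn(C)c(=O)c3ccccc23)nnc1SCC(=O)Nc1ccc(Cl)cc1Cl)OCC`: > 30000 nM
- compound 3, `Cn1nc(Cc2nnc(SCC(=O)Nc3ccc(Cl)cc3Cl)n2CCC=O)c2ccccc2c1=O`: 4200 nM

In an assay on NK92 cells for inhibition of interleukin-15 (Homo sapiens), read by AlphaScreen, with stated times of 30 min and 1 h (on this read-out lower numbers stand for stronger inhibition and higher numbers for weaker inhibition), compound 3 gives 4200 nM, the lowest of the two numbers recorded; compound 1 sits within the scatter of it, and the step of a 1.1-fold lower number from compound 1 to compound 3 (0.03 log units; within the scatter) is too small to call a difference. Compound 2 is recorded only as a limit, (the limit of > 30000 nM in this assay, at which 1 of the 3 values shown sits), not as a number.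

Compound 4, `Cn1nc(Cc2nnc(SCC(=O)Nc3ccc(Cl)cc3Cl)n2CCCO)c2ccccc2c1=O`, differs from compound 3 in one place: hydroxymethyl in place of formyl on a saturated chain carbon, two bonds along the chain from an aromatic nitrogen. Among the compounds with values here, two measured steps touch this chain. The step of a 1.1-fold lower number from compound 1 to compound 3 (0.03 log units; within the scatter) shows that adding a formylmethyl group to the bare chain carbon changes little, while the step of an at least 7.1-fold lower number from compound 2 to compound 3 (0.85 log units; beyond the scatter) shows that the bulkier diethoxymethyl end sits at the limit and the formyl end does not. A hydroxymethyl end is closer in size to formyl than to diethoxymethyl, so in this assay no step beyond the scatter is expected, the estimated step being a 1.1-fold lower number from compound 3 to compound 4 (0.02 log units; within the scatter). Compound 4 is therefore expected to give about 4000 nM, with a range from 1500 nM to 12000 nM.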

Compound 4, half-maximal inhibitory concentration: > 30000 nM
Compound 4: only a limit was reported; the forecaster's own chance of this, stated with the estimate: 10%; middle value at least 7.5-fold (0.87 log units) away from the limit.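

In this assay, the chain end turns out to be sensitive even to a swap that keeps the heavy-atom count: with hydroxymethyl in place of formyl, the result is an at least 7.1-fold higher number from compound 3 to compound 4 (0.85 log units; beyond the scatter). The earlier compounds shown here left open whether any chain here would be tolerated, and the 2-hydroxyethyl group now gives an at least 6.6-fold higher number from compound 1 to compound 4 (0.82 log units; beyond the scatter), whereas formylmethyl at that place made no difference beyond the scatter, so the outcome depends on the end of the chain and not on the chain alone. Compound 4 is recorded only as a limit, as is compound 2, so the step between them cannot be read, and the limit now holds both of them: the limit of > 30000 nM in this assay, at which 2 of the 4 values shown sit.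

The swap also adds a hydrogen-bond donor, but these compounds cannot separate that from the loss of the formyl group itself. As far as these compounds go, whether an amine, a carboxylic acid or a longer chain ending in formyl would stay with compound 3 or fall to the limit remains open.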